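Swapping the ring nitrogen substituent in a weak SMYD2 series

A few compounds are considered here, and "the series" means these few. Any claim that something is new, unique, unknown or untested is made for them only; others in the source may bear on it.

Within the data shown here, compound 1 `O=C1C=CC2(C=C1)OCC(Cc1cc(C(F)(F)F)cc(C(F)(F)F)c1)C(=O)N2c1ccccc1` is the only member of this set with a readable number: in an assay on isolated protein for inhibition of N-lysine methyltransferase SMYD2 (Homo sapiens), read by filter binding, with a stated time of 1 h (a lower number here means a stronger inhibitor, a higher number a weaker inhibitor), compound 1 gives 18500 nM. Compound 2 `CC(C)N1C(=O)C(Cc2ccc(Cl)cc2)COC12C=CC(=O)C=C2` reaches only the limit of the assay, giving > 20000 nM. Compound 3 `CC(C)N1C(=O)C(Cc2ccc(C#N)cc2)COC12C=CC(=O)C=C2` likewise reaches only the limit, giving > 20000 nM. The step that the two limits leave unreadable from compound 2 to compound 3 is therefore unreadable. Among the measured compounds shown here, compound 4 `CC(C)N1C(=O)C(Cc2cc(C(F)(F)F)cc(C(F)(F)F)c2)COC12C=CC(=O)C=C2` differs from compound 1 by isopropyl in place of phenyl on an amide-type nitrogen in a ring, a change no measured pair covers. The two compounds carrying isopropyl on that nitrogen, compound 2 and compound 3, both sit at the limit of > 20000 nM in this assay, at which 2 of the 3 values shown sit, so compound 4 is expected to show a small step toward weaker inhibition in this assay, a 1.4-fold higher number from compound 1 to compound 4 (0.13 log units; within the scatter). Compound 4 is estimated at 25000 nM, within 10000 nM to 60000 nM, with a real chance that only a limit is reported.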

Compound 4, half-maximal inhibitory concentration: 2390 nM
Compound 4: the middle estimate sits 10-fold (1.02 log units) above what was measured; the measured number lies below the stated range.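

In this assay, among these compounds, the nitrogen of the shared core proves sensitive to its substituent, giving the first readable step in this set: a 7.7-fold lower number from compound 1 to compound 4 (0.89 log units; beyond the scatter). With two trifluoromethyl groups on the aromatic ring, isopropyl on this nitrogen therefore goes with a readable number, which phenyl's replacement alone does not ensure. Compound 2 and compound 3 also carry isopropyl, yet each stays at a limit rather than a number: the limit of > 20000 nM in this assay, at which 2 of the 4 values shown sit. Going by these compounds, whether methyl, cyclopropyl or a longer chain on that nitrogen would lower the number further remains open.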